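Swapping 4-acetylphenyl for 4-nitrobenzyl: expectation for compound 4

The source may hold more compounds than are shown below. What is called first, only, known or untested is meant among the compounds shown, and "the series" means these compounds.

Within the data shown here, in a functional assay on A549 cells (Homo sapiens) for antiproliferative activity, read by MTT assay (on this read-out lower numbers stand for stronger inhibition and higher numbers for weaker inhibition), compound 1 `CC1(C)CCc2cc(C(=O)/C=C/c3ccc(OCc4cn(-c5ccc(Cl)cc5)nn4)cc3)c(O)cc2O1` gives 75500 nM and compound 2 `CC(=O)c1ccc(-n2cc(COc3ccc(/C=C/C(=O)c4cc5c(cc4O)OC(C)(C)CC5)cc3)nn2)cc1` gives 66300 nM on the numbers so far. Compound 3 `COc1ccc(-n2cc(COc3ccc(/C=C/C(=O)c4ccc5c(c4O)CCC(C)(C)O5)cc3)nn2)c([N+](=O)[O-])c1` differs from compound 1 in more than one place, and compound 3 stands as "not active" (no number reported) with no number reported. Compound 2 thus has a single numbered neighbour and sits level with it, the step being a 1.1-fold lower number from compound 1 to compound 2 (0.06 log units; within the scatter) for acetyl in place of chloro on an aromatic carbon.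

Compound 4 `CC1(C)CCc2cc(C(=O)/C=C/c3ccc(OCc4cn(Cc5ccc([N+](=O)[O-])cc5)nn4)cc3)c(O)cc2O1` departs from compound 2 at a different place, 4-nitrobenzyl in place of 4-acetylphenyl on an aromatic nitrogen with 4-nitrobenzyl in place of 4-acetylphenyl on an aromatic nitrogen. Among the measured compounds shown here, no measured step exchanges this whole group. For the measured compounds named here, the only measured step, a 1.1-fold lower number from compound 1 to compound 2 (0.06 log units; within the scatter) in size, changed a substituent on that group, so it bears on this change only loosely. Compound 3 at "not active" (no number reported) also shows that a number is not assured in this series. In this assay a 1.1-fold lower number from compound 2 to compound 4 (0.04 log units; within the scatter) is the expected step, which means no expected change beyond the scatter and no firm direction. For compound 4 the estimated value is 60000 nM with an expected range of 20000 nM to 150000 nM on present evidence.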

Compound 4, half-maximal inhibitory concentration: 35800 nM
For compound 4 the middle estimate is 1.7-fold (0.22 log units) above the measured one, and the stated range covers the measured number.
By their numbers in this assay, from the lowest: compounds 4, 2 and 1 (each within the scatter of the next, the first and the last beyond it).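

In this assay the exchange of a whole group on the aromatic nitrogen of the five-membered ring, rather than a substituent on that group, gives a 1.9-fold lower number from compound 2 to compound 4 (0.27 log units; within the scatter), so moving from 4-acetylphenyl to 4-nitrobenzyl leaves the number level. Among these compounds, the corresponding exchange from 4-chlorophenyl gives a 2.1-fold lower number from compound 1 to compound 4 (0.32 log units; beyond the scatter), the first step to pass the scatter, though only modestly, and it shows that a benzyl group as well as a phenyl group on this nitrogen can retain a numbered result. No available data bear on the reason for the size of either step.

The step from 4-chlorophenyl to 4-nitrobenzyl alters both the ring substituent and the way the ring is attached, and the compounds shown do not separate the two; 4-chlorobenzyl and 4-nitrophenyl on the same nitrogen would do so. Also open, from the compounds shown here alone, is whether this nitrogen can carry a group with no aromatic ring, such as an amine on a longer chain or a carboxylic acid, and whether such a group would move the number far from the level of compound 1, compound 2 and compound 4.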